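The compounds below may be only part of what the source reports. "The series", "measured", "known", "first", "only" and "open" are said of these compounds alone.

Measured so far in a functional assay on HFL1 cells for antagonist activity at sphingosine 1-phosphate receptor 2 (Homo sapiens), read by ELISA, with a stated time of 24 h, in the presence of a further agent that is not named here; on this read-out lower numbers stand for stronger inhibition and higher numbers for weaker inhibition:

compound 1, `C[C@@H](C(=O)O)c1nn(Cc2cn3cc(OCC4CC4)c(Cl)cc3n2)c2ccccc2c1=O`: 3180 nM
compound 2, `O=C(O)Cc1nn(Cc2cn3cc(OCC4CC4)c(Cl)cc3n2)c2ccccc2c1=O`: 60 nM
compound 3, `O=C(O)C1(c2nn(Cc3cn4cc(OCC5CC5)c(Cl)cc4n3)c3ccccc3c2=O)CC1`: 304 nM

Compound 3 holds the second highest of the three numbers. Its nearest neighbour is compound 2, separated by a 5.1-fold higher number from compound 2 to compound 3 (0.70 log units; beyond the scatter); its furthest is compound 1, separated by a 10-fold lower number from compound 1 to compound 3 (1.02 log units; beyond the scatter).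

Compound 4 is `C[C@H](C(=O)O)c1nn(Cc2cn3cc(OCC4CC4)c(Cl)cc3n2)c2ccccc2c1=O`. It differs from compound 3 by 1-carboxyethyl in place of 1-carboxycyclopropyl on an aromatic carbon. Among the compounds with values here, the entering group carries one defined stereocentre, and compound 4 is the configuration at that centre opposite to the one found in compound 1.

Within the data shown here, two measured steps bear on this change. The step of a 10-fold lower number from compound 1 to compound 3 (1.02 log units; beyond the scatter) is the same exchange run in reverse, but for the other configuration, so it sets only a rough reference. The step of a 5.1-fold higher number from compound 2 to compound 3 (0.70 log units; beyond the scatter) shows that the 1-carboxycyclopropyl group is itself already costly against the plain carboxymethyl of compound 2. Nothing measured separates the two configurations of the 1-carboxyethyl group, so the direction for compound 4 is open: it may sit close to compound 1, or it may recover toward compound 2.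

On balance a modest step is expected, a 1.3-fold higher number from compound 3 to compound 4 (0.12 log units; within the scatter), with wide uncertainty. Compound 4 is therefore estimated at 400 nM in this assay, within a range of 60 nM to 3200 nM.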

Compound 4, half-maximal inhibitory concentration: 19 nM
Compound 4: middle estimate off by 21-fold (1.32 log units), on the high side; the whole stated range lies above it.
By their numbers in this assay, from the lowest: compound 4; then compound 2; then compound 3; then compound 1.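

In this assay, the largest step in the series, a 170-fold lower number from compound 1 to compound 4 (2.22 log units; beyond the scatter), comes from stereochemistry alone: the fact that compounds 1 and 4 differ only in the configuration as drawn

A methyl on the saturated chain carbon is therefore not a penalty in itself: drawn S, it gives a 3.2-fold lower number from compound 2 to compound 4 (0.50 log units; beyond the scatter), whereas the R form of compound 1 lies on the weak side of the unsubstituted acid, with a 53-fold lower number from compound 1 to compound 2 (1.72 log units; beyond the scatter). Substitution at this carbon has no single direction, and compound 3 also goes against any simple gain from adding carbon there, since replacing 1-carboxycyclopropyl with the S 1-carboxyethyl group gives a 16-fold lower number from compound 3 to compound 4 (1.20 log units; beyond the scatter).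

The compounds shown leave open whether an ethyl group in place of the methyl, in the same S configuration, would keep or lose this gain, and whether a primary amide in place of the carboxylic acid would retain any activity. They also leave open whether the same gap between the two configurations would persist if the rest of the shared core were changed.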